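This account rests on a few compounds, and the source may have more. Where it says the series, first, only, none or still open, it means among the compounds named here.

Working notes on the series in a functional assay on KB cells (Homo sapiens) for cytotoxicity, read by MTT assay, with a stated time of 72 h (on this read-out lower numbers stand for an effect already at smaller amounts and higher numbers for an effect only at larger amounts of compound), follow. Compound 2 (`CCc1cccc2c(OC)c(-c3occ(C)c3C(=O)OC)ccc12`) gives 1.7 ug/mL and compound 3 (`CCOC(=O)c1c(C)coc1-c1ccc2c(CC)cccc2c1OC`) gives 2.2 ug/mL, so the two sit together at the low end of the numbers seen so far. For the measured compounds named here, compound 1 (`CCc1cccc2c(O)c(-c3occ(C)c3C(=O)O)ccc12`) gives 9.1 ug/mL, a clearly higher number than compound 2 shows, but it differs from compound 2 in more than one place and offers no clean step here.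

Compound 4 (`CCCOC(=O)c1c(C)coc1-c1ccc2c(CC)cccc2c1OC`) is still unmeasured. Its change from compound 2 is ethyl in place of hydrogen on a saturated chain carbon bound to an oxygen next to a carbonyl group (methoxycarbonyl to propoxycarbonyl, or methyl to propyl). Going by the values given here, one measured step bears on this place: a 1.3-fold higher number from compound 2 to compound 3 (0.11 log units; within the scatter) stayed within the scatter with methyl entering on the same carbon. Among the compounds with values here, that is a single step, and no measured compound yet carries a longer chain than the one in compound 3, so any trend with chain length remains untested. A small drift towards a higher number cannot be excluded, but no shift beyond the scatter is expected in this assay. The expected change is a 1.4-fold higher number from compound 2 to compound 4 (0.13 log units; within the scatter) on this estimate. For compound 4 the estimated value is 2.3 ug/mL within an expected range from 1.1 ug/mL to 4.6 ug/mL.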

Compound 4, concentration for half-maximal effect: > 10 ug/mL
Compound 4: only a limit was reported; the forecaster's own chance of this, stated with the estimate: 3%; middle value at least 4.3-fold (0.63 log units) from the limit.
By their numbers in this assay, from the lowest: compounds 2 and 3 (each within the scatter of the next); then compound 1. At a limit, above all of these: compound 4.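

In this assay the result for compound 4 is a limit and not a number: the limit of > 10 ug/mL in this assay, at which 1 of the 4 values shown sits.

Read against that limit, this place is no longer silent: with methyl entering on the saturated chain carbon bound to an oxygen next to a carbonyl group the series showed a 1.3-fold higher number from compound 2 to compound 3 (0.11 log units; within the scatter), whereas ethyl in place of hydrogen on that same carbon gives an at least 5.8-fold higher number from compound 2 to compound 4 (0.76 log units; beyond the scatter), and methyl on a saturated chain carbon, two bonds along the chain from that oxygen, gives an at least 4.5-fold higher number from compound 3 to compound 4 (0.65 log units; beyond the scatter). For the compounds shown here, the single earlier step therefore does not extend to propoxycarbonyl, and the last added methyl alone is enough to carry the number beyond the scatter.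

As far as these compounds go, the true size of both new steps stays open, since the limit gives only their lower bound. Also open, from the compounds shown here alone, is whether the number keeps rising with a longer chain such as butoxycarbonyl, and how a branched chain or an amide at this place would read in this assay.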